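Swapping chloro for amino: growth inhibition in three compounds

The source may report more compounds than this note shows. Statements on the series, on what has been measured and on what is new or still open speak of the compounds shown alone.

Measured so far:
Compound 1 `Nc1nc(Cl)c2ncn(Cc3ccc(CCl)cc3)c2n1`: in a functional assay on MOLT-4 cells (Homo sapiens) for cytotoxicity, read by sulforhodamine B assay, with a stated time of 48 h (on this read-out lower numbers stand for stronger inhibition of growth and higher numbers for weaker inhibition of growth), compound 1 reaches only the assay limit, > 100000 nM.
Compound 2 `ClCc1cccc(Cn2cnc3c(Cl)nc(Cl)nc32)c1`: in this assay compound 2 also gives only a limit, > 100000 nM.
Compound 3 `ClCc1ccc(Cn2cnc3c(Cl)nc(Cl)nc32)cc1`: in this assay compound 3 gives 27500 nM.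

Compound 3 is the only one of the three with a measured number. The change from compound 3 to compound 1, (amino in place of chloro on an aromatic carbon), made an at least 3.6-fold higher number from compound 3 to compound 1 (0.56 log units; beyond the scatter). Going by these compounds, that step runs into (the limit of > 100000 nM in this assay, at which 2 of the 3 values shown sit), so its true size is unknown.

Compound 4 `Nc1nc(Cl)c2ncn(Cc3cccc(CCl)c3)c2n1` is not yet measured. It arises from compound 2 by the same change, (amino in place of chloro on an aromatic carbon). How the core of compound 2 differs from the core of compound 3 is not broken down here.

Compound 2 already sits at the limit, and the same change lifted the number from compound 3 to compound 1, so compound 4 is expected to stay at or beyond that limit; the expected step is a step that the limit leaves unreadable from compound 2 to compound 4. Compound 4 is estimated at 150000 nM, most likely reported only as a limit.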

Compound 4, concentration for total growth inhibition: > 100000 nM
Compound 4 was reported as a limit; the forecaster's own chance of this, stated with the estimate: 85%; the middle value lies beyond the limit too.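

In this assay compound 4 gives > 100000 nM, which is a limit and not a number. Compound 2 also stands at a limit, so the swap of chloro for amino between compound 2 and compound 4 cannot be sized: the limit of > 100000 nM in this assay, at which 3 of the 4 values shown sit.

The compounds shown leave open how far past that limit compound 1, compound 2 and compound 4 really lie, and so whether this swap has the same size in both pairs.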